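The compounds below may be only part of what the source reports. "The series", "measured", "known", "first", "only" and "open" are said of these compounds alone.

Compound 1 `c1ccc2c(-c3cnc4[nH]nc(-c5nc6ccccc6[nH]5)c4c3)cncc2c1` gives 870 nM in a functional assay on A-375 cells (Homo sapiens) for antiproliferative activity (on this read-out lower numbers stand for stronger inhibition and higher numbers for weaker inhibition), the lower of the two numbers at hand. Compound 2 `Cc1cccc2[nH]c(-c3n[nH]c4ncc(-c5cncc6ccccc56)cc34)nc12` gives 1720 nM in this assay, and the step of a 2.0-fold higher number from compound 1 to compound 2 (0.30 log units; within the scatter) corresponds to a methyl in place of hydrogen on an aromatic carbon. Compound 3 `CN1CCN(c2ccc3[nH]c(-c4n[nH]c5ncc(-c6cncc7ccccc67)cc45)nc3c2)CC1` differs from compound 1 by 4-methylpiperazin-1-yl in place of hydrogen on an aromatic carbon. Among the measured compounds shown here, only the step from compound 1 to compound 2 bears on this change, and it stayed within the scatter, so no step beyond the scatter is expected in this assay for compound 3, a 1.2-fold lower number from compound 1 to compound 3 (0.09 log units; within the scatter). Compound 3 is therefore expected to give about 700 nM, between 200 nM and 2500 nM.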

Compound 3, half-maximal inhibitory concentration: 160 nM
Compound 3: middle estimate off by 4.4-fold (0.64 log units), on the high side, and the stated range ends above it.
By their numbers in this assay, from the lowest: compound 3; then compounds 1 and 2 (each within the scatter of the next).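

On this aromatic carbon of the six-membered carbon ring, 4-methylpiperazin-1-yl in place of hydrogen gives a clear change in this assay: a 5.4-fold lower number from compound 1 to compound 3 (0.74 log units; beyond the scatter). The methyl step, a 2.0-fold higher number from compound 1 to compound 2 (0.30 log units; within the scatter), had shown no change beyond the scatter, so this is the first sign that a substituent on the benzo part of the compound 1 scaffold can lower the number. No available evidence accounts for this gain. The compounds shown leave open which part of the group carries the step, and whether a morpholine, a piperidine or a simple dimethylamine on the same carbon would do the same.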